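The source may report more compounds than this note shows. Statements on the series, on what has been measured and on what is new or still open speak of the compounds shown alone.

Compound 1 `CCCCc1nc(=O)c(S(=O)(=O)c2ccc(-c3ccc(F)nc3)cc2)c(O)n1-c1c(OC)cccc1OC` and compound 2 `COc1cccc(OC)c1-n1c(CCC(C)C)nc(=O)c(S(=O)(=O)c2ccc(-c3ccc(F)nc3)cc2)c1O` share one core and differ only in their chain. In an ADME assay for permeability, using PAMPA, at pH 5.5 (a higher number here means that the compound crosses the layer faster, a lower number that the compound crosses the layer more slowly), compound 1 gives 516 nm/s, and compound 2 gives 246 nm/s, the lowest of the two numbers; the change is a 2.1-fold lower number from compound 1 to compound 2 (0.32 log units; beyond the scatter). Compound 3 `COc1cccc(OC)c1-n1c(COC(C)C)nc(=O)c(S(=O)(=O)c2ccc(-c3ccc(F)nc3)cc2)c1O` differs from compound 2 by isopropoxy in place of isobutyl on a saturated chain carbon bound to an aromatic carbon. Among the compounds with values here, no measured step here swaps a carbon for an oxygen in the chain, so the only guide is the general size of the one step seen. The estimated step is a 1.5-fold lower number from compound 2 to compound 3 (0.19 log units; within the scatter), giving an expected value for compound 3 of 160 nm/s, within 70 nm/s to 330 nm/s.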

Compound 3, apparent permeability: 75 nm/s
Beside the measured number, compound 3's estimate is 2.1-fold (0.33 log units) above it; the measured number falls inside the stated range.
By their numbers in this assay, from the lowest: compound 3; then compound 2; then compound 1.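

With the chain size held, isopropoxy in place of isobutyl gives a 3.3-fold lower number from compound 2 to compound 3 (0.52 log units; beyond the scatter) in this assay, so the two chains are not interchangeable at this place even though each has 4 heavy atoms. Set against the butyl chain of compound 1, the isopropoxy chain gives a 6.9-fold lower number from compound 1 to compound 3 (0.84 log units; beyond the scatter), the widest gap among these compounds. Nothing measured here accounts for this fall. Going by these compounds, whether an amine, a carboxylic acid or a longer ether chain at this place would lower the number in the same way remains open.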